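A few compounds are considered here, and "the series" means these few. Any claim that something is new, unique, unknown or untested is made for them only; others in the source may bear on it.

Compound 3 `CC(C)(O)c1cc2c(-c3ccc(C(F)(F)F)cc3)nccc2[nH]1` is one of three compounds built on the same shared core that have been measured in an ADME assay on U2OS cells (Homo sapiens) for cytotoxicity; on this read-out higher numbers stand for lower toxicity in this test and lower numbers for higher toxicity in this test. Compound 3 gives 72300 nM, the highest of the three numbers, which on this read-out means the lowest toxicity of the set. Its nearest neighbour is compound 1 `CC(C)(O)c1cc2c(-c3ccc(-c4ccccc4)c(F)c3)nccc2[nH]1`, which in this assay gives 9100 nM, and furthest from it lies compound 2 `CC(C)(O)c1cc2c(-c3ccc(NC(=O)OCc4ccccc4)cc3)nccc2[nH]1`, which in this assay gives 5500 nM. Both of those gaps to compound 3 are beyond the usual scatter, so compound 3 is genuinely the least toxic of the three here.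

Compound 4 `CC(C)(O)c1cc2c(-c3ccccc3)nccc2[nH]1` has not yet been measured. It differs from compound 3 in one place: hydrogen in place of trifluoromethyl on an aromatic carbon. The trifluoromethyl sits on an aromatic carbon of a six-membered aromatic ring of carbon only, para to a large group, and in compound 4 a hydrogen stands there instead. Within the data shown here, no step between measured compounds shows what such a change does in this assay, so any expectation rests on the set as a whole and on the size of the group removed. A small step is expected, within or only just beyond the scatter, and its direction is uncertain; the step of a 1.4-fold lower number from compound 3 to compound 4 (0.16 log units; within the scatter) is the estimate. For compound 4 in this assay a value of 50000 nM is expected, in a range from 15000 nM to 160000 nM.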

Compound 4, half-maximal cytotoxic concentration: 22200 nM
Beside the measured number, compound 4's estimate is 2.3-fold (0.35 log units) above it; the measured number falls inside the stated range.
By their numbers in this assay, from the lowest: compounds 2 and 1 (each within the scatter of the next); then compound 4; then compound 3.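

In this assay, among these compounds, the only step that changes a single place is a 3.3-fold lower number from compound 3 to compound 4 (0.51 log units; beyond the scatter), the result of hydrogen replacing trifluoromethyl on an aromatic carbon, para to a large group. This shows that what stands at this position matters in this test, as the number moves beyond the usual scatter, and that the compound carrying trifluoromethyl is the less toxic of this pair. Nothing measured here says why the number moves with this change.

As far as these compounds go, it remains open whether other groups at this position, such as a methyl group, a chlorine atom, a methoxy group or a nitrile, would keep the number near that of compound 3 or leave it near that of compound 4, so one step cannot show whether trifluoromethyl itself matters or whether any group larger than hydrogen would do. Also open, from the compounds shown here alone, is whether the same exchange would give a step of similar size if the shared core were altered elsewhere.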